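Notes on an isobutyl-thiazolyl isomer, compound 4

The source may hold more compounds than are shown below. What is called first, only, known or untested is meant among the compounds shown, and "the series" means these compounds.

Measured so far in a physicochemical assay for lipophilicity; on this read-out higher numbers stand for higher lipophilicity and lower numbers for lower lipophilicity:

- compound 1 `Cc1ccc(NC(=O)C[C@H](CCC(=O)O)c2noc(-c3cc(CC(C)C)no3)c2C2CC2)c(Cl)c1` gives 3.8
- compound 2 `Cc1ccc(NC(=O)C[C@H](CCC(=O)O)c2noc(-c3ncc(CC(C)C)o3)c2C2CC2)c(Cl)c1` gives 3.7
- compound 3 `Cc1ccc(NC(=O)C[C@H](CCC(=O)O)c2noc(-c3ncc(CC(C)C)s3)c2C2CC2)c(Cl)c1` gives 4

Compound 3 reads 4 and cannot be separated on these numbers from compound 1 or compound 2. The next structure is compound 4 `Cc1ccc(NC(=O)C[C@H](CCC(=O)O)c2noc(-c3csc(CC(C)C)n3)c2C2CC2)c(Cl)c1` which carries 2-isobutyl-1,3-thiazol-4-yl in place of 5-isobutyl-1,3-thiazol-2-yl on an aromatic carbon, with the same atoms joined differently 2-isobutyl-1,3-thiazol-4-yl in place of 5-isobutyl-1,3-thiazol-2-yl on an aromatic carbon and the rest of the molecule unchanged. Among the measured compounds shown here, no measured step is this exact exchange. The nearest evidence comes from the three exchanges already made on that same aromatic carbon: a number 0.10 log units lower from compound 1 to compound 2 (within the scatter) in the first case, a number 0.20 log units higher from compound 1 to compound 3 (within the scatter) in the second and a number 0.30 log units higher from compound 2 to compound 3 (within the scatter) in the third, so none of them leaves the scatter. In this assay no step beyond the scatter is therefore expected in either direction, and the reading of compound 3 at 4 is the starting point for the expectation. The estimated step is a number 0.10 log units lower from compound 3 to compound 4 (within the scatter) for now. For compound 4 the expected value is 3.9 with an estimated range from 3.6 to 4.2 on this read-out.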

Compound 4, distribution coefficient: 3.8
For compound 4 the middle estimate is 0.10 log units above the measured one; the measured number falls inside the stated range.
By their numbers in this assay, from the lowest: compounds 2, 1, 4 and 3 (each within the scatter of the next).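

In this assay, among the compounds shown here, the exchange with compound 4 is the first in which the same atoms are joined differently, with 2-isobutyl-1,3-thiazol-4-yl in place of 5-isobutyl-1,3-thiazol-2-yl, and the result is a number 0.20 log units lower from compound 3 to compound 4 (within the scatter); the earlier exchanges at this position replaced one kind of ring with another. Compound 4 also sits close to the two rings containing oxygen, with a number 0.10 log units higher from compound 2 to compound 4 (within the scatter) and no change at the digits printed from compound 1 to compound 4 (within the scatter), so all four isobutyl-bearing groups on this aromatic carbon, next to the ring oxygen and next to the ring atom that bears a cyclopropyl group, remain inseparable on this read-out. Nothing available offers an explanation for these readings.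

The compounds shown leave open whether this position can produce a step beyond the scatter at all, as every group here carries the same isobutyl chain; an amine, a carboxylic acid or a longer chain in its place would test that. They also leave open whether the four compounds, indistinguishable in this assay, differ on any other read-out.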